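A few compounds are considered here, and "the series" means these few. Any claim that something is new, unique, unknown or untested is made for them only; others in the source may bear on it.

Measured so far:
- compound 1, `N=C(N)c1ccc(-c2ccc(-c3cc(Cl)cc(Cl)c3)s2)s1`: 1700 nM
- compound 2, `COc1ccc(-c2ccc(-c3ccc(C(=N)N)o3)o2)cc1`: 1890 nM

Compound 1 and compound 2 share the same amidine end but differ in their ring chains and in their outer groups. In a functional assay on SF-539 cells (Homo sapiens) for inhibition, read by sulforhodamine B assay, with a stated time of 48 h (on this read-out lower numbers stand for stronger inhibition of growth and higher numbers for weaker inhibition of growth), compound 1 gives 1700 nM and compound 2 gives 1890 nM; compound 2 stands on the higher of the two numbers, yet the two values lie within the scatter of each other, so nothing can be read into the gap between them.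

Compound 3, `N=C(N)c1ccc(-c2ccc(-c3ccc(Cl)cc3)o2)o1`, has not yet been measured in this assay. It differs from compound 2 in one place: chloro in place of methoxy on an aromatic carbon. Going by the values given here, no step between measured compounds shows what such a swap does here; compound 1 carries chlorine on its outer ring but also a different core, so it cannot be compared one-to-one. The step from compound 2 to compound 3 is therefore expected to be small, a 1.4-fold lower number from compound 2 to compound 3 (0.13 log units; within the scatter), near the scatter with perhaps a slightly lower number. Compound 3 is estimated at 1400 nM, within 500 nM to 4000 nM.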

Compound 3, concentration for 50% growth inhibition: 1710 nM
The estimate for compound 3 lay 1.2-fold (0.09 log units) below the measured number, within the range that was stated.
By their numbers in this assay, from the lowest: compounds 1, 3 and 2 (each within the scatter of the next).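

Chloro in place of methoxy, on an aromatic carbon of a six-membered aromatic ring of carbon only and para to a large group, is the first swap in a single place that can be read in this assay and it gives a 1.1-fold lower number from compound 2 to compound 3 (0.04 log units; within the scatter) as the result. At this position the read-out therefore does not tell the two groups apart, even though the methoxy carries a hydrogen-bond acceptor and the chloro carries none. Nothing measured here bears on the reason for this result.

As far as these compounds go, whether an amine, a carboxylic acid or a longer chain such as butoxy would behave the same way at this position remains open. Also open, from the compounds shown here alone, is whether this swap would give a similar step on the core of compound 1, or what a replacement of the amidine end shared by all three compounds would do.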